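Two-compound series: assessing a benzylic substituent swap

This account rests on a few compounds, and the source may have more. Where it says the series, first, only, none or still open, it means among the compounds named here.

Measured so far:
- compound 1 `Cc1cc(Nc2cc(-c3ccccc3)[nH]n2)n2nc(SCc3ccc([N+](=O)[O-])cc3)nc2n1`: 43600 nM
- compound 2 `Cc1cc(Nc2ccn(Cc3ccccc3)n2)n2nc(SCc3ccc(Br)cc3)nc2n1`: 44400 nM

In an ADME assay on GES1 cells (Homo sapiens) for inhibition, read by MTT assay, with a stated time of 72 h (on this read-out lower numbers stand for stronger inhibition and higher numbers for weaker inhibition), compound 1 gives 43600 nM and compound 2 gives 44400 nM; the two numbers lie within the scatter of each other, so neither can be placed ahead of the other. Compound 1 carries the lowest number of the two, but only by a margin that repeated measurements would not resolve. Among the measured compounds shown here, no single-change step between measured compounds exists here, so there is no calibrated step to lean on.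

Compound 3 `Cc1cc(Nc2cc(-c3ccccc3)[nH]n2)n2nc(SCc3ccc(C(F)(F)F)cc3)nc2n1` has not yet been run. Its structure differs from compound 1 in one place: trifluoromethyl in place of nitro on an aromatic carbon. The replaced group sits on an aromatic carbon of a six-membered aromatic ring of carbon only, para to a large group.

For the measured compounds named here, with only two measured compounds, both at a similar level, the expectation for this change is a step of no more than the scatter in either direction. The step expected from the change is a 1.0-fold higher number from compound 1 to compound 3 (0.01 log units; within the scatter). Compound 3 is therefore estimated at 45000 nM in this assay, with a range of 20000 nM to 100000 nM.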

Compound 3, half-maximal inhibitory concentration: 42700 nM
Compound 3: middle estimate off by 1.1-fold (0.02 log units), on the high side; low and high end bracket the measured number.
By their numbers in this assay, from the lowest: compounds 3, 1 and 2 (each within the scatter of the next).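

Working notes on the benzylic substituent. In this assay, among the compounds shown here, the exchange of nitro for trifluoromethyl gives a 1.0-fold lower number from compound 1 to compound 3 (0.01 log units; within the scatter), the first single-change step, and it shows that this position tolerates the swap with no readable shift in the number. The two groups are not close in their counted features: a group of 3 heavy atoms with 2 hydrogen-bond acceptors and a double bond gives way to one of 4 heavy atoms with 0 hydrogen-bond acceptors, so on this aromatic carbon, para to a large group, that difference in make-up leaves the read-out unmoved in this pair. Nothing available explains why the two compounds read alike, so the step stands as an observation only.

Still open, from the compounds shown here alone, is whether an amine, a carboxylic acid or a plain hydrogen on the same aromatic carbon would also stay within the scatter, or whether such a group would finally move the number. A single step also leaves open whether trifluoromethyl and nitro would read alike on a different core, such as one carrying a longer chain at the sulfur.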